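The source may report more compounds than this note shows. Statements on the series, on what has been measured and on what is new or still open speak of the compounds shown alone.

Working notes on the series. Compound 1 `O=C(Nc1cccc(-n2cc(-c3ccncc3)c(-c3ccc(Cl)c(O)c3)n2)c1)Nc1ccc(Cl)c(Cl)c1` was tested in a functional assay on SW-620 cells (Homo sapiens) for inhibition, read by sulforhodamine B assay, with a stated time of 48 h; on this read-out lower numbers stand for stronger inhibition of growth and higher numbers for weaker inhibition of growth; for compound 1 the result is only a limit of the assay, > 32500 nM. Compound 2 `COc1cc(-c2nn(-c3cccc(NC(=O)c4ccc(Cl)c(C(F)(F)F)c4)c3)cc2-c2ccncc2)ccc1Cl` likewise returns only a limit in this assay, namely > 32500 nM. Going by the values given here, compound 2 therefore stands nowhere on a numerical scale: the two values shown both sit at the limit, as the limit of > 32500 nM in this assay, at which 2 of the 2 values shown sit, records, and no step between measured compounds can be drawn from them.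

Compound 3 `COc1cc(-c2nn(-c3cccc(NC(=O)Nc4ccc(Cl)c(C(F)(F)F)c4)c3)cc2-c2ccncc2)ccc1Cl` has not yet been measured in this assay. Relative to compound 2 the change is (4-chloro-3-(trifluoromethyl)phenyl)amino in place of 4-chloro-3-(trifluoromethyl)phenyl on a carbonyl carbon. Nothing measured in the series supports a move in either direction, because compound 1 and compound 2 both sit at the limit (the limit of > 32500 nM in this assay, at which 2 of the 2 values shown sit). The expected step from compound 2 to compound 3 in this assay is a step that the limit leaves unreadable from compound 2 to compound 3, which amounts to nothing beyond the scatter. Compound 3 is accordingly expected to give about 40000 nM in this assay, with a range from 15000 nM to 100000 nM, and most probably only a limit will again be reported for compound 3.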

Compound 3, concentration for total growth inhibition: 29900 nM
For compound 3 the middle estimate is 1.3-fold (0.13 log units) above the measured one, within the range that was stated.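

In this assay compound 3 gives 29900 nM as a true number, the first in the series that is not a limit of the assay. On the carbonyl carbon, (4-chloro-3-(trifluoromethyl)phenyl)amino in place of 4-chloro-3-(trifluoromethyl)phenyl thus gives a readable end point, and the step is an at least 1.0-fold lower number from compound 2 to compound 3 (0.03 log units; that floor lies within the scatter), which is only a floor and does not establish a real change. As far as these compounds go, the true size of this step stays unknown because compound 2 remains a limit: the limit of > 32500 nM in this assay, at which 2 of the 3 values shown sit.

From the compounds shown here alone, whether another group on the same carbonyl carbon, such as cyclohexylamino, n-butylamino or a morpholine, would give a number clearly apart from that of compound 3 remains open. Also open, going by these compounds, is whether a carboxylic acid or a primary amine on the aromatic ring of the (4-chloro-3-(trifluoromethyl)phenyl)amino group, in place of its chlorine or trifluoromethyl, would bring growth inhibition into a range well clear of the limit.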